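The compounds below may be only part of what the source reports. "The series", "measured", "known", "first", "only" and "open" are said of these compounds alone.

Compound 2, with the structure `COc1cc(-c2nn(-c3cccc(NC(=O)Nc4ccc(Cl)c(Cl)c4)c3)cc2-c2ccncc2)ccc1Cl`, was tested in a functional assay on SNB-19 cells (Homo sapiens) for inhibition, read by sulforhodamine B assay, with a stated time of 48 h (on this read-out higher numbers stand for lower toxicity in this test and lower numbers for higher toxicity in this test), and there compound 2 reached only > 50000 nM, which is a limit of the test and not a measured number. Its companion, compound 1, with the structure `COc1cc(-c2nn(-c3cccc(NC(=O)Nc4cc(C(F)(F)F)cc(C(F)(F)F)c4)c3)cc2-c2ccncc2)ccc1Cl`, likewise gave in this assay a result of > 50000 nM, again a limit rather than a number. Thus both compounds sit at the limit of > 50000 nM in this assay, at which 2 of the 2 values shown sit, so no ordering between them can be drawn from what has been shown. Compound 3, with the structure `COc1cc(-c2nn(-c3cccc(NC(=O)Nc4cccc(C(F)(F)F)c4)c3)cc2-c2ccncc2)ccc1Cl`, has not yet been tested in this assay. It differs from compound 2 in one place: 3-(trifluoromethyl)phenyl in place of 3,4-dichlorophenyl on an amide-type nitrogen. Among the compounds with values here, with no measured step available between compounds that differ in one place, the expected change from compound 2 to compound 3 in this assay is a step that the limit leaves unreadable from compound 2 to compound 3, that is, none beyond the scatter. For compound 3 the expected result in this assay is therefore 60000 nM, within a range from 25000 nM to 150000 nM.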

Compound 3, concentration lethal to 50% of the cells: > 50000 nM
Compound 3: a limit, no number; the forecaster's own chance of this, stated with the estimate: 70%; the middle value does not contradict the limit.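

Compound 3 also gives a limit and not a number, so the steps from compound 1 and from compound 2 to compound 3 cannot be read: the limit of > 50000 nM in this assay, at which 3 of the 3 values shown sit. The compounds shown leave open whether compound 1, compound 2 and compound 3 differ at all in this assay.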